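From hydroxymethyl to 2-oxopyrrolidin-1-yl at an assay limit

The source may hold more compounds than are shown below. What is called first, only, known or untested is meant among the compounds shown, and "the series" means these compounds.

Compound 1 `Cc1noc(-c2nc(C)c3c(c2N)C(=O)N(Cc2ccc(-n4cccn4)cc2)C3=O)n1` gives < 5000 nM (a limit)
Compound 2 `Cc1noc(-c2nc(C)c3c(c2N)C(=O)N(Cc2ccc(CO)cc2)C3=O)n1` gives < 5000 nM (a limit)

In a physicochemical assay for solubility, using the shake flask method, in simulated intestinal fluid, measured as kinetic solubility, with a stated time of 2 h, at 25 degrees C, at pH 6.5 (a higher number here means a more soluble compound, a lower number a less soluble compound), compound 2 gives < 5000 nM as a limit and not as a number, so its standing is known only that far. Compound 3 `Cc1noc(-c2nc(C)c3c(c2N)C(=O)N(Cc2ccc(N4CCCC4=O)cc2)C3=O)n1` carries 2-oxopyrrolidin-1-yl in place of hydroxymethyl on an aromatic carbon, para to a large group, and the change counts as 2-oxopyrrolidin-1-yl in place of hydroxymethyl on an aromatic carbon in full. Among the compounds with values here, the only measured step at an aromatic carbon is a step that the two limits leave unreadable from compound 1 to compound 2 and it offers no size to carry over. No step beyond the scatter can therefore be expected in this assay in either direction. Compound 3 is expected to be reported as a limit as well because the limit of < 5000 nM in this assay, at which 2 of the 2 values shown sit, and nothing measured points elsewhere. The expected change is a step that the limit leaves unreadable from compound 2 to compound 3 and it is only an estimate. For compound 3 the estimated value is 3000 nM with an expected range from 1000 nM to 8000 nM in this estimate.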

Compound 3, solubility: < 5000 nM
Compound 3 ended at the assay's limit (the forecaster's own chance of this, stated with the estimate: 80%); the middle value does not contradict the limit.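

No step can be read among compound 1, compound 2 and compound 3 in this assay because all three stand at the same limit: the limit of < 5000 nM in this assay, at which 3 of the 3 values shown sit. The compounds shown leave open where each one lies under that limit, and so whether exchanging these groups on the aromatic carbon changes the read-out at all.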